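The source may report more compounds than this note shows. Statements on the series, on what has been measured and on what is new or still open speak of the compounds shown alone.

Compound 1 `O=C1[C@@H](NS(=O)(=O)c2ccc(-c3ccccn3)s2)CCN1Cc1cc2[nH]cccc-2n1` has the lower of the two measured numbers: in an assay on isolated protein for inhibition of coagulation factor X (Oryctolagus cuniculus), tested at 1 uM (on this read-out lower numbers stand for less inhibition and higher numbers for more inhibition at the one concentration tested (going by the name of the read-out)), compound 1 gives 8%, while compound 2 `O=C1[C@@H](NS(=O)(=O)c2ccc(-c3ccncc3)s2)CCN1Cc1cc2[nH]cccc-2n1` gives 35% in this assay. Among the measured compounds shown here, the one measured step, a number 27 percentage points higher from compound 1 to compound 2 (beyond the scatter), concerns a change on a different part of the molecule, and so it says nothing about the change considered here.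

Compound 3 `O=C1[C@@H](NS(=O)(=O)c2ccc(-c3ccccn3)s2)CCN1Cc1cc2cc[nH]cc-2n1` differs from compound 1 by a group of 9 heavy atoms (7 carbon, 2 nitrogen; one five-membered aromatic ring with 1 hetero atom, one six-membered aromatic ring with 1 hetero atom) in place of a group of 9 heavy atoms (7 carbon, 2 nitrogen; one five-membered aromatic ring with 1 hetero atom, one six-membered aromatic ring with 1 hetero atom), on a saturated chain carbon bound to an amide-type nitrogen in a ring. For the measured compounds named here, no measured pair shows what such a rearrangement of the bicyclic group does in this assay, so there is no step to lean on. The change is therefore expected to give no step beyond the scatter, and a number 2 percentage points higher from compound 1 to compound 3 (within the scatter) is the estimated outcome. On that basis, compound 3 is expected to give about 10% in this assay, with a likely range from 0% to 35%.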

Compound 3, a percentage reported as inhibition, at one concentration (the size of the read-out at that concentration, not a potency): 17%
Estimate against measurement, compound 3: 7 percentage points below, within the range that was stated.
By their numbers in this assay, from the lowest: compounds 1 and 3 (each within the scatter of the next); then compound 2.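

Among the compounds shown here, the step of a number 9 percentage points higher from compound 1 to compound 3 (within the scatter) in this assay gives the first reading at this position. It shows that this rearrangement of the bicyclic group, on a saturated chain carbon bound to an amide-type nitrogen in a ring, does not separate the two compounds on this read-out, even though the atoms of the group are joined differently. The earlier step concerned only pyridin-4-yl in place of pyridin-2-yl, so this is a separate finding about a different part of the molecule. No measurement at hand offers an explanation for this result.

From the compounds shown here alone, it remains open whether a plainer group at the same place, such as a phenyl ring or an aminopyridine, would change the number beyond the scatter. Also open, going by these compounds, is how the rearranged bicyclic group behaves when combined with pyridin-4-yl.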